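The source may hold more compounds than are shown below. What is called first, only, known or untested is meant among the compounds shown, and "the series" means these compounds.

Measured so far in an ADME assay on Vero cells (Chlorocebus sabaeus) for cytotoxicity, read by resazurin assay, with a stated time of 3 days; a higher number here means a weaker inhibitor, a lower number a stronger inhibitor:
compound 1 `CCCCNC(=O)Nc1cc2nc(C3CCCCC3)[nH]c2cc1N(CC)CC` — > 100 ug/mL
compound 2 `CCOCCOC(=O)Nc1cc2nc(C3CCCCC3)[nH]c2cc1N(C)C` — > 100 ug/mL
compound 3 `CCCOCC(=O)Nc1cc2nc(C3CCCCC3)[nH]c2cc1N(C)C` — < 50 ug/mL

Compound 1 sits at > 100 ug/mL, which is a limit of this assay and not a number. Compound 2 also reports a limit, > 100 ug/mL. Compound 3 reports < 50 ug/mL, again a limit. Among the compounds with values here, the single measured step, an at least 2.0-fold lower number from compound 2 to compound 3 (0.30 log units; that floor lies within the scatter), concerns the carbonyl-side group, not the urea chain, and its floor lies within the scatter. Two of the three values stand at the limit of > 100 ug/mL in this assay, at which 2 of the 3 values shown sit, and one at the limit of < 50 ug/mL in this assay, at which 1 of the 3 values shown sits.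

Compound 4 `CCCNC(=O)Nc1cc2nc(C3CCCCC3)[nH]c2cc1N(CC)CC` differs from compound 1 by hydrogen in place of methyl on a saturated chain carbon, three bonds along the chain from an amide-type nitrogen. Within the data shown here, no measured step bears on this change, so no shift beyond the scatter is expected: a step that the limit leaves unreadable from compound 1 to compound 4 is the expected step. Compound 4 is estimated at 150 ug/mL, within 70 ug/mL to 300 ug/mL.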

Compound 4, half-maximal inhibitory concentration: > 100 ug/mL
Compound 4: only a limit was reported; the forecaster's own chance of this, stated with the estimate: 85%; the middle value is on the limit's open side.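

Compound 4 gives > 100 ug/mL, a limit and not a number. Compound 1 also reports a limit, so no step can be read between compound 1 and compound 4. Going by these compounds, whether butyl to propyl shifts the value at all remains open.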